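The source may report more compounds than this note shows. Statements on the series, on what has been measured and on what is new or still open speak of the compounds shown alone.

Of the compounds shown here, two anchor the series so far. Among the compounds with values here, in a functional assay on PC-3 cells (Homo sapiens) for cytotoxicity, read by WST assay, with a stated time of 48 h (on this read-out higher numbers stand for weaker inhibition and lower numbers for stronger inhibition), compound 1 `COc1ccc2c(/C=C(\C#N)C(=O)c3c[nH]c4ccccc34)c[nH]c2c1` gives 12500 nM, the only true number available. Compound 2 `N#C/C(=C\c1cn(Cc2ccc(Cl)cc2)c2ccccc12)C(=O)c1c[nH]c2cc(F)ccc12` reads > 50000 nM, which is a limit of the assay and not a number. Going by these compounds, it therefore stands at the limit of > 50000 nM in this assay, at which 1 of the 2 values shown sits, and its real position remains open.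

The next compound is compound 3 `COc1ccc2c(C(=O)/C(C#N)=C/c3cn(Cc4ccc(Cl)cc4)c4ccccc34)c[nH]c2c1`, reached from compound 2 by one exchange: methoxy in place of fluoro on an aromatic carbon, or 6-fluoro-1H-indol-3-yl to 6-methoxy-1H-indol-3-yl (methoxy in place of fluoro on an aromatic carbon). Within the data shown here, no measured pair isolates this exchange, so any expectation is loose. Compound 1, at 12500 nM, also carries a methoxy but differs from compound 3 elsewhere too, so it serves only as a rough guide. A modest move toward stronger inhibition in this assay is expected, though a second reading at the limit would be no surprise. The expected step, an at least 2.2-fold lower number from compound 2 to compound 3 (0.35 log units; beyond the scatter), is an estimate measured from a limit and carries that uncertainty. Compound 3 is estimated at 22000 nM, within a range of 6000 nM to 50000 nM.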

Compound 3, half-maximal inhibitory concentration: > 50000 nM
Compound 3: only a limit was reported (the forecaster's own chance of this, stated with the estimate: 40%); at least 2.2-fold (0.35 log units) between middle value and limit.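

In this assay compound 3 gives > 50000 nM, a limit of the assay and not a number. Compound 2 also reads as a limit, so no step can be read between compound 2 and compound 3: the limit of > 50000 nM in this assay, at which 2 of the 3 values shown sit. Going by these compounds, the true positions of both compounds remain open, as does whether methoxy in place of fluoro on an aromatic carbon shifts inhibition at all.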